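Removing the Chlorine From Compound 1

This account rests on a few compounds, and the source may have more. Where it says the series, first, only, none or still open, it means among the compounds named here.

Of the compounds shown here, two have been measured in a functional assay on K562 cells (Homo sapiens) for antiproliferative activity; a higher number here means a weaker inhibitor, a lower number a stronger inhibitor. Compound 2 `C=C(Br)C(=O)Nc1ccc2sc(C(=O)O)cc2c1` gives 5000 nM in this assay. Compound 1 `C=C1CC(COc2cc(C(=O)O)n(C)n2)(c2ccc(Cl)cc2)OC1=O` does not reach a number at all: it sits at the limit of the assay, > 10000 nM, which is the limit of > 10000 nM in this assay, at which 1 of the 2 values shown sits. Compound 3 `C=C1CC(COc2cc(C(=O)O)n(C)n2)(c2ccccc2)OC1=O` is the same as compound 1 except for one change, (hydrogen in place of chloro on an aromatic carbon), that is hydrogen in place of chloro on an aromatic carbon. For the measured compounds named here, no measured pair shows what this change does, so its size cannot be read from the data. With compound 1 already at the limit, the expected step is a step that the limit leaves unreadable from compound 1 to compound 3, which is taken to be no larger than the scatter and, if anything, toward weaker inhibition. Compound 3 is therefore estimated at 15000 nM in this assay, within a range from 5000 nM to 50000 nM, and most likely again reported only as a limit.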

Compound 3, half-maximal inhibitory concentration: > 10000 nM
Compound 3: a limit, no number (the forecaster's own chance of this, stated with the estimate: 70%); the middle value is on the limit's open side.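

No step can be read from compound 1 to compound 3, because each gives only a limit and no number: the limit of > 10000 nM in this assay, at which 2 of the 3 values shown sit. The compounds shown leave open how far, if at all, going from 4-chlorophenyl to phenyl shifts antiproliferative potency.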